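A Smaller Aryl Group at the Assay's Limit

The source may hold more compounds than are shown below. What is called first, only, known or untested is meant among the compounds shown, and "the series" means these compounds.

Compound 1 `COc1cc2c(cc1OC)CN(CCn1cc(COc3cccc4ccccc34)nn1)CC2` and compound 2 `COc1cc2c(cc1OC)CN(CCn1cc(COc3ccc(C(C)(C)C)cc3)nn1)CC2` share a core and differ only in the group on an oxygen on a saturated carbon. In an ADME assay on K562 cells (Homo sapiens) for cytotoxicity, read by MTT assay, with a stated time of 48 h (a lower number here means a stronger inhibitor, a higher number a weaker inhibitor), compound 1 gives > 100000 nM, which is a limit and not a number. Compound 2 gives > 100000 nM, also a limit. Both compounds stand at the same point: the limit of > 100000 nM in this assay, at which 2 of the 2 values shown sit. Among the compounds with values here, the only measured step, a step that the two limits leave unreadable from compound 1 to compound 2, therefore has no size to carry forward.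

Compound 3 `COc1cc2c(cc1OC)CN(CCn1cc(COc3ccc(C)cc3C)nn1)CC2` has 2,4-dimethylphenyl in place of 4-(tert-butyl)phenyl on an oxygen on a saturated carbon. Within the data shown here, neither compound 1 nor compound 2 gives a number, so no measured step points to a change in either direction, and no step beyond the scatter is expected. The expected step is a step that the limit leaves unreadable from compound 2 to compound 3. Compound 3 is estimated at 120000 nM, within an expected range of 40000 nM to 300000 nM, and will probably be reported only as a limit.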

Compound 3, half-maximal inhibitory concentration: > 100000 nM
Compound 3 ended at the assay's limit; the forecaster's own chance of this, stated with the estimate: 75%; the middle value is on the limit's open side.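

No step among compound 1, compound 2 and compound 3 can be read, as each result is a limit and not a number: the limit of > 100000 nM in this assay, at which 3 of the 3 values shown sit.

The compounds shown leave open whether any group on this oxygen can bring a readable number in this assay.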